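The source may hold more compounds than are shown below. What is called first, only, known or untested is meant among the compounds shown, and "the series" means these compounds.

Compound 1 `O=Cc1cn(C[C@H]2CN(c3ccc(C4=CCS(=O)(=O)CC4)c(F)c3)C(=O)O2)nn1` gives 3200 nM in an assay for binding affinity to Amine oxidase [flavin-containing] A (Homo sapiens); on this read-out higher numbers stand for weaker inhibition and lower numbers for stronger inhibition. Compound 2 `O=C1O[C@@H](Cn2cc(Cl)nn2)CN1c1ccc(C2=CCS(=O)(=O)CC2)c(F)c1` gives 3000 nM. Compound 3 `O=C1O[C@@H](Cn2cc(CO)nn2)CN1c1ccc(C2=CCS(=O)(=O)CC2)c(F)c1` gives 47000 nM.

Among these three, the number for compound 1 is the second highest, with compound 2 close to it, a 1.1-fold lower number from compound 1 to compound 2 (0.03 log units; within the scatter), and compound 3 far from it, a 15-fold higher number from compound 1 to compound 3 (1.17 log units; beyond the scatter). Compound 4 `O=C1O[C@@H](Cn2cc(Br)nn2)CN1c1ccc(C2=CCS(=O)(=O)CC2)c(F)c1` differs from compound 1 by bromo in place of formyl on an aromatic carbon. Among the measured compounds shown here, the step that bears most on this is the one from compound 1 to compound 2, a 1.1-fold lower number from compound 1 to compound 2 (0.03 log units; within the scatter), where a halogen took the place of the formyl group and nothing moved beyond the scatter; the step to hydroxymethyl, a 16-fold higher number from compound 2 to compound 3 (1.19 log units; beyond the scatter), was large but concerns a different group. Compound 4 is therefore expected to show no step beyond the scatter, a 1.1-fold lower number from compound 1 to compound 4 (0.03 log units; within the scatter). The estimate for compound 4 is 3000 nM, with a range from 1500 nM to 6500 nM.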

Compound 4, inhibition constant: 16000 nM
The estimate for compound 4 lay 5.3-fold (0.73 log units) below the measured number; measured number outside the range, above it.
By their numbers in this assay, from the lowest: compounds 2 and 1 (each within the scatter of the next); then compound 4; then compound 3.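

In this assay, the halogens at this aromatic carbon do not behave as one: a 5.3-fold higher number from compound 2 to compound 4 (0.73 log units; beyond the scatter), so the match between chloro and formyl does not extend to bromo. Bromo also parts from formyl, a 5.0-fold higher number from compound 1 to compound 4 (0.70 log units; beyond the scatter), yet it does not reach the level of hydroxymethyl, a 2.9-fold lower number from compound 3 to compound 4 (0.47 log units; beyond the scatter), which places it at an intermediate level among these four compounds. No evidence is available to explain the gap between bromo and chloro. On these data alone, whether fluoro or iodo would sit with chloro or with bromo remains open. So does where an amine, a carboxylic acid or a longer chain would fall at this carbon.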